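Notes on the ring-nitrogen substituent series: compound 3

A few compounds are considered here, and "the series" means these few. Any claim that something is new, unique, unknown or untested is made for them only; others in the source may bear on it.

Measured so far in a functional assay on the whole organism for inhibition, with Rattus norvegicus as the target; a lower number here means that less compound is needed, a higher number that more compound is needed for the effect:
compound 1 `NC(=O)n1cc(C(=O)c2ccn3c2CSC3c2cccnc2)c2ccc(-c3ccc(F)cc3)cc21`: 0.06 mg/kg
compound 2 `CN(C)C(=O)Cn1cc(C(=O)c2ccn3c2CSC3c2cccnc2)c2ccc(-c3ccc(F)cc3)cc21`: 0.12 mg/kg

Compound 2 stands with the higher of the two numbers, its nearest neighbour being compound 1; the step of a 2.0-fold higher number from compound 1 to compound 2 (0.30 log units; within the scatter) is within the scatter, so the two compounds are not separated on this assay.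

Compound 3 `O=C(O)CCn1cc(C(=O)c2ccn3c2CSC3c2cccnc2)c2ccc(-c3ccc(F)cc3)cc21` differs from compound 2 by carboxymethyl in place of dimethylcarbamoyl on a saturated chain carbon bound to an aromatic nitrogen. For the measured compounds named here, the only measured step, from compound 1 to compound 2, exchanges a different group at the same chain and lies within the scatter, so it gives no direct guide to an acid in place of a dimethylcarbamoyl. Going by the values given here, with no measured step bearing on this exchange, the working expectation is a number close to that of compound 2, with wide uncertainty in both directions. The estimated step of a 1.3-fold higher number from compound 2 to compound 3 (0.10 log units; within the scatter) is therefore expected to stay near the scatter. For compound 3 the estimate in this assay is 0.15 mg/kg, with a range from 0.04 mg/kg to 0.6 mg/kg.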

Compound 3, dose for half-maximal effect: 5.1 mg/kg
Compound 3: the middle estimate sits 34-fold (1.53 log units) below what was measured; measured number above the stated range.
By their numbers in this assay, from the lowest: compounds 1 and 2 (each within the scatter of the next); then compound 3.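

In this assay, this position proved sensitive to the group on the chain: a 43-fold higher number from compound 2 to compound 3 (1.63 log units; beyond the scatter) follows from carboxymethyl in place of dimethylcarbamoyl on a saturated chain carbon bound to an aromatic nitrogen, whereas the earlier 2.0-fold higher number from compound 1 to compound 2 (0.30 log units; within the scatter) did not separate the two compounds. The comparison with the carbamoyl compound points the same way, with 2-carboxyethyl giving an 85-fold higher number from compound 1 to compound 3 (1.93 log units; beyond the scatter), so the carboxylic acid compound stands well apart from both amide-bearing compounds. No supporting measurement is available to explain this change.

The compounds shown leave open whether the large steps follow from the carboxylic acid itself or from the removal of the amide, a question that a methyl ester or a primary amide on the same chain would address. On these data alone, how a longer chain bearing the carboxylic acid, or an amine at its end, would read in this assay also remains open.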